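The source may report more compounds than this note shows. Statements on the series, on what has been measured and on what is new or still open speak of the compounds shown alone.

Compound 3 `CCN(Cc1ccccc1)c1cccc(C(=O)N2CCc3ccc(OS(N)(=O)=O)cc3C2)c1` gives 69% in an assay on HEK293 cells for inhibition of Steryl-sulfatase (Homo sapiens), tested at 1 uM (on this read-out higher numbers stand for a stronger effect at the one concentration tested and lower numbers for a weaker effect), the second highest of the three numbers. Compound 2 `CCN(Cc1ccc(Br)cc1)c1cccc(C(=O)N2CCc3ccc(OS(N)(=O)=O)cc3C2)c1` gives 84.5%, and compound 1 `CCN(Cc1cccc(Br)c1)c1cccc(C(=O)N2CCc3ccc(OS(N)(=O)=O)cc3C2)c1` gives 24.9%. Compound 4 `CN(CCCN1CCCCC1)c1cccc(C(=O)N2CCc3ccc(OS(N)(=O)=O)cc3C2)c1` differs from compound 3 in one place: methyl(3-(piperidin-1-yl)propyl)amino in place of benzyl(ethyl)amino on an aromatic carbon. The measured steps all concern a bromo on the benzyl group: a number 59.6 percentage points higher from compound 1 to compound 2 (beyond the scatter), a number 44.1 percentage points higher from compound 1 to compound 3 (beyond the scatter) and a number 15.5 percentage points lower from compound 2 to compound 3 (beyond the scatter). None of them exchanges the benzyl group itself for a chain, so they give no direct guide to this change; they show only that this part of the molecule can move the read-out a great deal in either direction. Compound 4 is therefore expected near the middle of the measured span, with wide uncertainty, at 50%, between 15% and 85%, which corresponds to an expected step of a number 19 percentage points lower from compound 3 to compound 4 (beyond the scatter).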

Compound 4, a percentage reported as inhibition, at one concentration (the size of the read-out at that concentration, not a potency): 30.6%
Compound 4: the middle estimate sits 19.4 percentage points above what was measured; low and high end bracket the measured number.
By their numbers in this assay, from the lowest: compounds 1 and 4 (each within the scatter of the next); then compound 3; then compound 2.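

Replacing the whole benzyl(ethyl)amino group, not just a bromo on it, also moves the read-out in this assay, giving a number 38.4 percentage points lower from compound 3 to compound 4 (beyond the scatter) and a number 53.9 percentage points lower from compound 2 to compound 4 (beyond the scatter). Yet the step of a number 5.7 percentage points higher from compound 1 to compound 4 (within the scatter) shows that two very different groups, one with an aromatic ring and one with a piperidine chain, can give similar numbers. Nothing available explains these results. From the compounds shown here alone, it remains open whether the loss of the aromatic ring or the arrival of the piperidine chain matters more; a diethylamino group, or the same propyl chain ending in morpholine, would help separate the two.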